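The source may report more compounds than this note shows. Statements on the series, on what has been measured and on what is new or still open speak of the compounds shown alone.

Among the compounds with values here, in a functional assay on A549 cells (Homo sapiens) for antiproliferative activity, read by luminescence and CellTiter-Glo, with a stated time of 48 h (on this read-out lower numbers stand for stronger inhibition and higher numbers for weaker inhibition), compound 2 (`O=C1C=CC[C@H]([C@@H]2C[C@H]2c2ccccc2)O1`) gives 62800 nM, the only actual number among the three compounds measured so far. Compound 1 (`O=C1CCC[C@@H]([C@H]2C[C@@H]2c2ccccc2)O1`) gives > 100000 nM, which is a limit of the assay and not a number. Compound 3 (`O=C1CCC[C@H]([C@@H]2C[C@H]2c2ccccc2)O1`) gives > 100000 nM, which is also a limit.

Compound 4 (`O=C1C=CC[C@@H]([C@H]2C[C@@H]2c2ccccc2)O1`) is the mirror image of compound 2: the two compounds have the same atoms and bonds and differ only in configuration as drawn: 3 of 3 stereo elements differ (all stereocentres are inverted: mirror images); a stereocentre at a saturated ring carbon is drawn R in compound 2 and S in compound 4; a stereocentre at a saturated ring carbon is drawn R in compound 2 and S in compound 4; a stereocentre at a saturated ring carbon is drawn R in compound 2 and S in compound 4. Within the data shown here, only one measured pair involves the same kind of inversion, and it shows a step that the two limits leave unreadable from compound 1 to compound 3. Its size cannot be read because of the limit of > 100000 nM in this assay, at which 2 of the 3 values shown sit, although the pair is relevant through (the fact that compounds 1 and 3 differ only in the configuration as drawn). From the compounds shown here alone, the data therefore give neither a size nor a direction for inverting all stereocentres, so no step beyond the scatter is expected in this assay, although a move either way remains open. For compound 4, the expected value is 60000 nM, with an estimated range of 22000 nM to 100000 nM. This estimate means an expected 1.0-fold lower number from compound 2 to compound 4 (0.02 log units; within the scatter).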

Compound 4, half-maximal inhibitory concentration: 15200 nM
Compound 4: middle estimate off by 3.9-fold (0.60 log units), on the high side; the whole stated range lies above it.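

The mirror-image pair gives the first readable size for inverting all stereocentres in this assay, with a 4.1-fold lower number from compound 2 to compound 4 (0.62 log units; beyond the scatter). Configuration alone therefore changes the read-out here, and the lower number belongs to compound 4, the form drawn S at all three stereocentres: the fact that compounds 2 and 4 differ only in the configuration as drawn. The earlier mirror-image pair could show neither a size nor a direction, since both of its members stand at a limit of the assay and not at a number: the limit of > 100000 nM in this assay, at which 2 of the 4 values shown sit.

From the compounds shown here alone, whether the same direction holds for compound 1 and compound 3 remains open, as their step cannot be read. Also open, going by these compounds, is whether the lower number of compound 4 would persist if an amine or a carboxylic acid were added to the shared core.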